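Acetyl in place of methyl on a diaryl urea

The source may hold more compounds than are shown below. What is called first, only, known or untested is meant among the compounds shown, and "the series" means these compounds.

The measured compounds:
compound 1, `Cc1cccc(NC(=O)N[C@H](C)c2ccccc2)c1`, gives 100% in an ADME assay on the whole organism with Oryza sativa as the target, tested at 0.1 uM; a lower number here means a stronger effect, a higher number a weaker effect of the compound at the concentration tested
compound 2, `Cc1cccc(NC(=O)N[C@@H](C)c2ccccc2)c1`, gives 99%
compound 3, `CC(=O)c1ccccc1NC(=O)N[C@@H](C)c1ccccc1`, gives 100%

Compound 1 stands level with compound 3 at the digits shown, and the two are together the highest of the three numbers. Among the measured compounds shown here, the one step that has been measured, a number 1 percentage points lower from compound 1 to compound 2 (within the scatter), lies within the scatter; the only difference behind it is the fact that compounds 1 and 2 differ only in the configuration as drawn, so this step says nothing about what a change of substituent does.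

Compound 4, `CC(=O)c1cccc(NC(=O)N[C@H](C)c2ccccc2)c1`, is still to be measured. Compared with compound 1 it carries acetyl in place of methyl on an aromatic carbon. For the measured compounds named here, no measured step bears directly on this change, since the pair of compound 1 and compound 3 is not a single-point difference and no step is given for it. What the two values show is that compound 3, which also carries an acetyl group, sits at the same high reading as compound 1.

On that basis compound 4 is expected to stay where compound 1 already is, and the estimated step of a number 1 percentage points lower from compound 1 to compound 4 (within the scatter) is expected to fall within the scatter. The estimate for compound 4 is 99%, with a range from 88% to 100%.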

Compound 4, a percentage reported as activity, at one concentration (the size of the read-out at that concentration, not a potency): 98%
Compound 4: middle estimate off by 1 percentage points, on the high side, and the stated range covers the measured number.
By their numbers in this assay, from the lowest: compounds 4, 2, 1 and 3 (each within the scatter of the next).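

In this assay, acetyl in place of methyl on an aromatic carbon, meta to a large group, gives a number 2 percentage points lower from compound 1 to compound 4 (within the scatter) and so leaves the two readings indistinguishable. Among the compounds shown here, this is the first step that changes a substituent rather than the configuration as drawn, and it shows that at this position the reading does not separate the two groups, even though acetyl brings more heavy atoms and a hydrogen-bond acceptor that methyl lacks. Nothing at hand speaks to the reason for this outcome.

One step at a single position cannot show whether the rest of the core would tolerate the same change, or whether acetyl would behave in the same way with the stereocentre drawn the other way. As far as these compounds go, it also remains open whether a quite different group at this position, such as an amine, a carboxylic acid or a longer chain, would give a clearly lower number, which would mean a stronger effect at the concentration tested.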